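A carbamoyl group on the series of compound 2

The source may hold more compounds than are shown below. What is called first, only, known or untested is meant among the compounds shown, and "the series" means these compounds.

Compound 1 `N#Cc1c(NN)nc(SCc2nc3ccccc3[nH]2)nc1-c1ccccc1` gives 2.68 nM
Compound 2 `N#Cc1c(NNC(N)=S)nc(SCc2nc3ccccc3[nH]2)nc1-c1ccccc1` gives 2.55 nM

In a functional assay on GOTO cells (Homo sapiens) for cytotoxicity, read by MTT assay, with a stated time of 3 days (a higher number here means a weaker inhibitor, a lower number a stronger inhibitor), compound 2 stands at 2.55 nM and compound 1 at 2.68 nM on one level, within the scatter of each other. Compound 3 `N#Cc1c(NC(N)=O)nc(SCc2nc3ccccc3[nH]2)nc1-c1ccccc1` has not yet been measured and differs from compound 2 in one place. The change is a group of 3 heavy atoms (1 carbon, 1 nitrogen, 1 oxygen; no ring) in place of a group of 4 heavy atoms (1 carbon, 2 nitrogen, 1 sulfur; no ring), on a nitrogen on an aromatic ring in which carbamoyl enters on a nitrogen on an aromatic ring. Going by the values given here, one measured step bears on it, a 1.1-fold lower number from compound 1 to compound 2 (0.02 log units; within the scatter) and that step, made in the same side chain, stayed within the scatter. Among the compounds with values here, no measured compound carries a carbamoyl group, so this evidence is thin. A step beyond the scatter in this assay is therefore not expected in either direction. The expected step is a 1.2-fold higher number from compound 2 to compound 3 (0.07 log units; within the scatter) with wide uncertainty. Compound 3 is expected at 3 nM within an estimated range of 1 nM to 10 nM for now.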

Compound 3, half-maximal inhibitory concentration: 11.3 nM
Beside the measured number, compound 3's estimate is 3.8-fold (0.58 log units) below it, outside the stated range (above it).
By their numbers in this assay, from the lowest: compounds 2 and 1 (each within the scatter of the next); then compound 3.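

In this assay, the substituent on this nitrogen on an aromatic ring is not indifferent: carbamoyl gives a 4.4-fold higher number from compound 2 to compound 3 (0.65 log units; beyond the scatter) and, measured against the amino group, a 4.2-fold higher number from compound 1 to compound 3 (0.62 log units; beyond the scatter). Going by these compounds alone, compound 1 and compound 2 had stayed on one level, so this is the first change at this position to go beyond the scatter, and carbamoyl alone stands apart from the other two side chains. Nothing shown here accounts for this difference.

The step from compound 2 to compound 3 exchanges sulfur for oxygen and removes a nitrogen from the chain together, so the compounds shown cannot separate the two changes. On these data alone, a semicarbazide chain, which keeps the chain of compound 2 with oxygen in place of sulfur, or an acetyl group on the same nitrogen, remains open.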